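The compounds below may be only part of what the source reports. "The series", "measured", "known", "first", "only" and "open" are said of these compounds alone.

In a functional assay on HepG2 cells (Homo sapiens) for cytotoxicity, read by MTT assay, with a stated time of 48 h (on this read-out higher numbers stand for weaker inhibition and lower numbers for stronger inhibition), the three measured compounds give:

compound 1, `CC1=NN(C(=O)c2ccc(C)cc2)C(c2cc(Br)ccc2O)C1`: 23200 nM
compound 2, `CC[N+](C)(CC)CC(=O)N1N=C(C)CC1c1ccccc1OC`: 3670 nM
compound 3, `CCC(=O)N1N=C(c2cc3ccccc3oc2=O)CC1c1ccccc1`: 9610 nM

Compound 3 holds the second highest number of the three in this assay. Compound 1 sits above it, and that gap is beyond the usual scatter of repeated measurements. Compound 2 sits below compound 3, again by a gap beyond the scatter, and so gives the lowest number of the three.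

Compound 4, `CCN(CC)C1CCN(CC(=O)N2N=C(c3cc4ccccc4oc3=O)CC2c2ccccc2)CC1`, has not been measured in this assay. It differs from compound 3 in one place: 4-(diethylamino)piperidin-1-yl in place of methyl on a saturated chain carbon bound to a carbonyl carbon. For the measured compounds named here, no single-change step between measured compounds exists to calibrate this change, so the expectation rests on the spread of numbers seen so far. A modest move toward a lower number is expected, a 1.9-fold lower number from compound 3 to compound 4 (0.28 log units; within the scatter), a step that may not exceed the scatter. For compound 4 the expected value in this assay is 5000 nM, with a range from 1500 nM to 15000 nM.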

Compound 4, half-maximal inhibitory concentration: 19300 nM
Beside the measured number, compound 4's estimate is 3.9-fold (0.59 log units) below it; measured number outside the range, above it.
By their numbers in this assay, from the lowest: compound 2; then compounds 3, 4 and 1 (each within the scatter of the next, the first and the last beyond it).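

Putting 4-(diethylamino)piperidin-1-yl in place of methyl on a saturated chain carbon bound to a carbonyl carbon gives a 2.0-fold higher number from compound 3 to compound 4 (0.30 log units; within the scatter) in this assay, so the two compounds cannot be told apart on this read-out. For the compounds shown here, this is the first single-change comparison here, and it shows that a group of 11 heavy atoms, carrying a six-membered non-aromatic ring and 2 hydrogen-bond acceptors, can replace a single methyl at this place without a step beyond the scatter. Nothing available explains this result.

Going by these compounds alone, with only this one step at this place, it remains open whether a smaller group such as morpholin-4-yl or dimethylamino, or a carboxylic acid, would give a step beyond the scatter. Going by these compounds, whether the same change would give a similar step on a different core also remains open.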